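Benzyl-substituted nucleoside series: antiproliferative read-outs at the limit

The source may hold more compounds than are shown below. What is called first, only, known or untested is meant among the compounds shown, and "the series" means these compounds.

Compound 1 `OC[C@H]1O[C@@H](n2cnc3c(NCc4cccc(F)c4)ncnc32)[C@H](O)[C@@H]1O`, compound 2 `OC[C@H]1O[C@@H](n2cnc3c(NCc4ccccc4Br)ncnc32)[C@H](O)[C@@H]1O` and compound 3 `Cc1cccc(CNc2ncnc3c2ncn3[C@@H]2O[C@H](CO)[C@@H](O)[C@H]2O)c1` share one core and differ only in the group on the saturated chain carbon bound to a nitrogen on an aromatic ring. In a functional assay on G-361 cells (Homo sapiens) for antiproliferative activity, with a stated time of 72 h (on this read-out lower numbers stand for stronger inhibition and higher numbers for weaker inhibition), compound 1 gives > 166000 nM, which is a limit of the measurement and not a number. In this assay compound 2 gives > 166000 nM, again a limit. In this assay compound 3 gives > 166000 nM, also a limit. Compound 3 thus stands where the other two stand, at the limit of > 166000 nM in this assay, at which 3 of the 3 values shown sit, and the steps a step that the two limits leave unreadable from compound 1 to compound 2, a step that the two limits leave unreadable from compound 1 to compound 3 and a step that the two limits leave unreadable from compound 2 to compound 3 are all unreadable in size.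

Compound 4 `OC[C@H]1O[C@@H](n2cnc3c(NCc4ccc(F)c(F)c4F)ncnc32)[C@H](O)[C@@H]1O` is not yet measured. It differs from compound 3 by 2,3,4-trifluorophenyl in place of 3-methylphenyl on a saturated chain carbon bound to a nitrogen on an aromatic ring. For the measured compounds named here, no measured step bears readably on this change; every step in the set is hidden by the limit. A like outcome is expected: compound 4 is estimated at 200000 nM in this assay, with a range from 100000 nM to 500000 nM, and most probably only a limit will be reported. The step that the limit leaves unreadable from compound 3 to compound 4 is expected to fall within the scatter.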

Compound 4, half-maximal inhibitory concentration: > 166000 nM
Compound 4 was reported as a limit (the forecaster's own chance of this, stated with the estimate: 85%); the middle value lies beyond the limit too.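

In this assay compound 4 gives > 166000 nM as a limit of the measurement. For the compounds shown here, no step from compound 1, compound 2 or compound 3 to compound 4 can be read. The compounds shown leave open whether any group at this place on the shared core gives a measurable antiproliferative value.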